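Swapping a Ring Sulfur for Carbon on a Thiosemicarbazide

The source may hold more compounds than are shown below. What is called first, only, known or untested is meant among the compounds shown, and "the series" means these compounds.

Compound 1, with the structure `Cc1ccnc(/C(N)=N/NC(=S)N2CCSCC2)c1`, was tested in a functional assay on A-375 cells (Homo sapiens) for cytotoxicity, read by MTT assay, with a stated time of 72 h (a higher number here means a weaker inhibitor, a lower number a stronger inhibitor), where compound 1 gives 1200 nM. Among the compounds with values here, only one other compound has been measured: compound 2, `N/C(=N\NC(=S)N1CCSCC1)c1ccccn1`, which in this assay gives 760 nM. The step of a 1.6-fold lower number from compound 1 to compound 2 (0.20 log units; within the scatter) comes from hydrogen in place of methyl on an aromatic carbon, so the two numbers sit within the scatter of each other and neither can be called stronger.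

Compound 3, `Cc1ccnc(/C(N)=N/NC(=S)N2CCCCC2)c1`, has not yet been measured. Compared with compound 1 the change is piperidin-1-yl in place of thiomorpholin-4-yl on a thiocarbonyl carbon. Within the data shown here, no measured step touches this part of the molecule; the single recorded step, from compound 1 to compound 2, concerns the methyl on the aromatic ring and says nothing about the ring attached to the thiocarbonyl carbon. With nothing bearing on it, the expectation in this assay is a change no larger than the scatter, in no particular direction. Compound 3 is therefore estimated at 1200 nM, with a range from 450 nM to 3200 nM. The expected step is no change at the digits printed from compound 1 to compound 3 (within the scatter).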

Compound 3, half-maximal inhibitory concentration: 1900 nM
Compound 3: the middle estimate sits 1.6-fold (0.20 log units) below what was measured; low and high end bracket the measured number.
By their numbers in this assay, from the lowest: compounds 2, 1 and 3 (each within the scatter of the next, the first and the last beyond it).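

Within the data shown here, this is the first look at the ring on the thiocarbonyl carbon, as the earlier step concerned only the methyl on the aromatic ring. In this assay, piperidin-1-yl in place of thiomorpholin-4-yl gives a 1.6-fold higher number from compound 1 to compound 3 (0.20 log units; within the scatter), so exchanging the ring sulfur for carbon leaves the two compounds indistinguishable in this read-out. For this one pair, then, a ring with one hetero atom and no hydrogen-bond acceptor does as well as a ring with two hetero atoms and one hydrogen-bond acceptor, and nothing available explains the result.

From the compounds shown here alone, how much wider a change this place can accept stays open: morpholin-4-yl, with oxygen where thiomorpholin-4-yl has its sulfur, piperazin-1-yl, with a second ring nitrogen, or an open-chain dimethylamino group would each probe it further. Whether the same exchange would give a similar step on the core of compound 2, which carries hydrogen in place of the methyl, also remains an open question.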